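This account rests on a few compounds, and the source may have more. Where it says the series, first, only, none or still open, it means among the compounds named here.

So far, three related compounds have been measured in a physicochemical assay for lipophilicity, measured as octanol-water partition, at pH 7.4; a lower number here means a more polar compound, a higher number a more lipophilic compound. There compound 1 (`Cc1ccc2[nH]c(C(=O)N[C@H]3CN(S(=O)(=O)c4ccnc(C)c4)C[C@@H]3C(=O)NCCN(C)C)cc2c1`) gives 1.7 and compound 2 (`Cc1ccc2[nH]c(C(=O)N[C@@H]3CN(S(=O)(=O)c4ccccc4)C[C@H]3C(=O)NCCN(C)C)cc2c1`) gives 2.1 while compound 3 (`Cc1csc(C(=O)N[C@H]2CN(S(=O)(=O)c3ccccc3)C[C@@H]2C(=O)N[C@H]2CCCNC2)n1`) gives 0.1 and stands lowest of the three, with both gaps beyond the scatter. The next compound, compound 4 (`O=C(N[C@H]1CN(S(=O)(=O)c2ccccc2)C[C@@H]1C(=O)N[C@H]1CCCNC1)c1cc(-c2ccccc2)on1`), has 5-phenyl-1,2-oxazol-3-yl in place of 4-methyl-1,3-thiazol-2-yl on a carbonyl carbon and is otherwise the same as compound 3. The entering group brings one six-membered aromatic ring of carbon only, which the leaving group does not have. No measured pair among these compounds shows this change, so the expectation rests on the structures alone. Among the measured compounds shown here, a rise beyond the scatter is expected, and the estimated step is a number 1.10 log units higher from compound 3 to compound 4 (beyond the scatter) with no measured step to check it against. Compound 4 is therefore expected at 1.2 with an estimated range from 0.6 to 1.9 in this measurement.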

Compound 4, distribution coefficient: 1.3
For compound 4 the middle estimate is 0.10 log units below the measured one; low and high end bracket the measured number.
By their numbers in this assay, from the lowest: compound 3; then compound 4; then compound 1; then compound 2.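

Among the compounds shown here, this is the first pair here that differs in one place, so the group on the carbonyl carbon now has a direct reading in this assay: 5-phenyl-1,2-oxazol-3-yl in place of 4-methyl-1,3-thiazol-2-yl gives a number 1.20 log units higher from compound 3 to compound 4 (beyond the scatter), a large step. The two groups match in their counts of hydrogen-bond donors and acceptors and in having no net charge, and the entering group adds one six-membered aromatic ring of carbon only. Nothing available here explains the size of this step.

This single pair changes the added ring, the methyl group and the sulfur-to-oxygen swap together, so it cannot separate their contributions. Going by these compounds, a 5-methyl-1,2-oxazol-3-yl group at this place could help separate them, and its number remains open.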